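Adding a Chloro to the Core of Compound 3

The source may report more compounds than this note shows. Statements on the series, on what has been measured and on what is new or still open speak of the compounds shown alone.

compound 1, `ClCc1ccc(Cn2cnc3c(Cl)ncnc32)cc1`, in a functional assay on NCI-H23 cells (Homo sapiens) for cytotoxicity, read by sulforhodamine B assay, with a stated time of 48 h (a higher number here means that more compound is tolerated, a lower number that less compound is tolerated), gives 7760 nM
compound 2, `ClCc1ccccc1Cn1cnc2c(Cl)ncnc21`, in this assay gives 9330 nM
compound 3, `ClCc1cccc(Cn2cnc3c(Cl)ncnc32)c1`, in this assay gives 8710 nM

Three compounds share one core and differ only in where the side arm is attached to its ring. Compound 3 holds the second highest of the three numbers. Its number lies close to that of compound 2 and close to that of compound 1, and both gaps fall within the scatter of repeated measurements, so the three compounds cannot be told apart on these figures.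

Compound 4, `ClCc1cccc(Cn2cnc3c(Cl)nc(Cl)nc32)c1`, has not yet been measured in this assay. It differs from compound 3 by a single change: chloro in place of hydrogen on an aromatic carbon. Among the compounds with values here, no pair among the measured compounds shows this exchange, so the present numbers give no guide to its effect. The expected step from compound 3 to compound 4 is accordingly a 1.2-fold lower number from compound 3 to compound 4 (0.06 log units; within the scatter), that is, no shift beyond the scatter in either direction. Compound 4 is thus estimated at 7500 nM in this assay, with a range from 2500 nM to 22000 nM.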

Compound 4, concentration lethal to 50% of the cells: 22400 nM
Compound 4: middle estimate off by 3.0-fold (0.48 log units), on the low side, and the stated range ends below it.
By their numbers in this assay, from the lowest: compounds 1, 3 and 2 (each within the scatter of the next); then compound 4.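

Placing a chloro on the aromatic carbon between two ring nitrogen atoms of the shared core gives, in this assay, a 2.6-fold higher number from compound 3 to compound 4 (0.41 log units; beyond the scatter), the first difference among these compounds that lies beyond the scatter. Compound 1, compound 2 and compound 3 had shown only that the attachment point of the side arm on its ring leaves the numbers indistinguishable, whereas this single exchange on the core shows that the position can move the read-out, and that here it moves towards more compound being tolerated. Nothing in the data presented accounts for why this exchange has that effect.

Going by these compounds, this reading rests on one pair, so it remains open whether a methyl, an amine or a methoxy group at the same carbon would shift the number in the same way, or whether the step is particular to chloro. On these data alone, it also remains open whether the same exchange would produce a similar step on the core of compound 1 or of compound 2, where the side arm is attached differently.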